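Inverting one ring stereocentre in a Substance-P antagonist series

The compounds below may be only part of what the source reports. "The series", "measured", "known", "first", "only" and "open" are said of these compounds alone.

Compound 1: `CC(=O)N1C(C)CN(c2nc3c(c(-c4ccccc4C)n2)C(=O)N(Cc2cc(C(F)(F)F)cc(C(F)(F)F)c2)C[C@@H](C)CO3)CC1C` — 52.9 nM
Compound 2: `Cc1ccccc1-c1ncnc2c1C(=O)N(Cc1cc(C(F)(F)F)cc(C(F)(F)F)c1)C[C@H](C)CO2` — 12.6 nM
Compound 3: `Cc1ccccc1-c1nc(N(C)C)nc2c1C(=O)N(Cc1cc(C(F)(F)F)cc(C(F)(F)F)c1)C[C@H](C)CO2` — 0.427 nM
Compound 4: `CC(=O)N1C(C)CN(c2nc3c(c(-c4ccccc4C)n2)C(=O)N(Cc2cc(C(F)(F)F)cc(C(F)(F)F)c2)C[C@H](C)CO3)CC1C` — not yet measured

In a functional assay on ileum for antagonist activity at Substance-P receptor (Cavia porcellus) (on this read-out higher numbers stand for weaker inhibition and lower numbers for stronger inhibition), compound 1 gives 52.9 nM, the highest of the three numbers; compound 2 gives 12.6 nM, and compound 3 gives 0.427 nM. Within the data shown here, the one measured step, a 30-fold lower number from compound 2 to compound 3 (1.47 log units; beyond the scatter), concerns a substituent on an aromatic carbon and does not touch stereochemistry. Compound 4 differs from compound 1 only in that (the two compounds have the same atoms and bonds; at least one stereo element is drawn with a configuration in one of them and without one in the other: 1 of 3 stereo elements differ; a stereocentre at a saturated ring carbon is drawn R in compound 1 and S in compound 4). Among the measured compounds shown here, no measured pair addresses this change directly, so its size cannot be read from a step. What the structures do show is that compound 2 and compound 3, both with lower numbers than compound 1, are drawn with the same configuration at that ring carbon as compound 4. On that basis compound 4 is expected to give a lower number than compound 1, an 11-fold lower number from compound 1 to compound 4 (1.02 log units; beyond the scatter), with considerable uncertainty. The estimate for compound 4 in this assay is 5 nM, within a range of 0.8 nM to 30 nM.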

Compound 4, antagonist equilibrium constant: 0.217 nM
Compound 4: middle estimate off by 23-fold (1.36 log units), on the high side, and the stated range ends above it.
By their numbers in this assay, from the lowest: compounds 4 and 3 (each within the scatter of the next); then compound 2; then compound 1.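

In this assay, the configuration at this saturated ring carbon proves decisive for the series: with atoms and bonds unchanged, drawing it S rather than R gives a 240-fold lower number from compound 1 to compound 4 (2.39 log units; beyond the scatter). With the S configuration, the group of 11 heavy atoms on the aromatic carbon gives a 58-fold lower number from compound 2 to compound 4 (1.76 log units; beyond the scatter) when it replaces hydrogen, while replacing dimethylamino gives only a 2.0-fold lower number from compound 3 to compound 4 (0.29 log units; within the scatter), so this assay does not separate those two groups. The size of the inversion step carries one caution about how the structures are drawn: the fact that one of compounds 1 and 4 is drawn with a defined configuration and the other without, at the place where they differ.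

From the compounds shown here alone, compounds 2 and 3 have no partner drawn R, so the size of the inversion with hydrogen or dimethylamino on the aromatic carbon stays open. Going by these compounds, whether a morpholine or a carboxylic acid on that carbon would give a comparably low number also stays open.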